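The compounds below may be only part of what the source reports. "The series", "measured", "known", "first", "only" and "open" are said of these compounds alone.

Working notes on the series. In a functional assay on SNB-19 cells (Homo sapiens) for inhibition, read by sulforhodamine B assay, with a stated time of 48 h, tested at 0.1 uM (a higher number here means a weaker effect of the compound at the concentration tested, a lower number a stronger effect), compound 1 `COc1cc(Cl)cc(-c2nn(-c3cccc(NC(=O)Nc4ccc(Cl)c(Cl)c4)c3)cc2-c2ccncc2)c1` gives 90%. In this assay compound 2 `COc1cc(Cl)cc(-c2nn(-c3cccc(NC(=O)Nc4cccc(C(F)(F)F)c4)c3)cc2-c2ccncc2)c1` gives 96%, the highest of the two numbers shown, with compound 1 within the scatter of it. Among the measured compounds shown here, the single measured step, a number 6 percentage points higher from compound 1 to compound 2 (within the scatter), changes the group on the amide-type nitrogen and stays within the scatter. Compound 3 `COc1cc(Cl)cc(-c2nn(-c3cccc(NC(=O)c4cccc(C(F)(F)F)c4)c3)cc2-c2ccncc2)c1` differs from compound 2 by 3-(trifluoromethyl)phenyl in place of (3-(trifluoromethyl)phenyl)amino on a carbonyl carbon. For the measured compounds named here, no measured step touches the carbonyl carbon, so the only guide is that step; no change beyond the scatter in this assay is expected. Compound 3 is expected at 94%, in a range from 84% to 104%. The expected step is a number 2 percentage points lower from compound 2 to compound 3 (within the scatter).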

Compound 3, a percentage reported as activity, at one concentration (the size of the read-out at that concentration, not a potency): 97%
Compound 3: middle estimate off by 3 percentage points, on the low side, and the stated range covers the measured number.
By their numbers in this assay, from the lowest: compounds 1, 2 and 3 (each within the scatter of the next).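

In this assay, the carbonyl carbon accepts 3-(trifluoromethyl)phenyl in place of (3-(trifluoromethyl)phenyl)amino with a number 1 percentage points higher from compound 2 to compound 3 (within the scatter), so losing that nitrogen and its hydrogen-bond donor does not separate the two compounds. The change from the (3,4-dichlorophenyl)amino group gives a number 7 percentage points higher from compound 1 to compound 3 (within the scatter), which also does not separate them. No supporting data bear on this result. Still open, on these data alone, is whether a saturated amine such as piperidine or a carboxylic acid on the aryl ring of this group would move the read-out beyond the scatter. A single concentration also leaves open how these compounds compare at other concentrations.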